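A few compounds are considered here, and "the series" means these few. Any claim that something is new, unique, unknown or untested is made for them only; others in the source may bear on it.

Measured compounds:
Compound 1, `CCCCCc1ccc(-c2cn(C/C=C3\OC(=O)C(OCc4ccccc4)=C3OCc3ccccc3)nn2)cc1`: in a functional assay on A549 cells (Homo sapiens) for antiproliferative activity, read by MTT assay, with a stated time of 72 h (a higher number here means a weaker inhibitor, a lower number a stronger inhibitor), compound 1 gives > 100000 nM.
Compound 2, `CCCCCc1ccc(-c2cn(C[C@H](O)[C@H]3OC(=O)C(OCc4ccccc4)=C3OCc3ccccc3)nn2)cc1`: in this assay compound 2 gives 6220 nM.

For the measured compounds named here, compound 2 holds the only number measured in this assay. The value of compound 1 is a limit of the assay rather than a number; the record shows (the limit of > 100000 nM in this assay, at which 1 of the 2 values shown sits). Going by the values given here, no step between measured compounds that differ in one place is known, so compound 2 alone anchors the comparison.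

Compound 3, `O=C1O[C@H]([C@@H](O)Cn2cc(-c3cc(F)cc(F)c3)nn2)C(OCc2ccccc2)=C1OCc1ccccc1`, is not yet measured in this assay. It differs from compound 2 in one change: 3,5-difluorophenyl in place of 4-pentylphenyl on an aromatic carbon. The shared core is untouched; only the group on the five-membered aromatic ring with 3 nitrogen changes.

Expected as a 2.4-fold higher number from compound 2 to compound 3 (0.38 log units; beyond the scatter), this step is judged to fall beyond the usual scatter, toward weaker inhibition. Compound 3 is therefore estimated at 15000 nM in this assay, within a range from 4000 nM to 60000 nM.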

Compound 3, half-maximal inhibitory concentration: 41200 nM
Compound 3: the middle estimate sits 2.7-fold (0.44 log units) below what was measured; the range from low to high includes it.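

Replacing 4-pentylphenyl with 3,5-difluorophenyl on this aromatic carbon gives a 6.6-fold higher number from compound 2 to compound 3 (0.82 log units; beyond the scatter) in this assay, so this position of the five-membered aromatic ring with 3 nitrogen is not indifferent to the group it carries. The change still leaves a measured number rather than a limit, as compound 3 gives 41200 nM, so the read-out at this position survives the loss of the pentyl chain. Nothing measured here accounts for the size of this step.

With only these two groups at this position, the compounds shown cannot separate the loss of the pentyl chain from the entry of the two fluorines. A plain phenyl, a 4-fluorophenyl or a 4-hexylphenyl on the same carbon would bear on that question.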